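The source may report more compounds than this note shows. Statements on the series, on what has been measured and on what is new or still open speak of the compounds shown alone.

Working notes on the series. In a functional assay on 1321-N1 cells for agonist activity at P2Y purinoceptor 2 (Homo sapiens), read by scintillation counting and inositol phosphate accumulation (on this read-out lower numbers stand for an effect already at smaller amounts and higher numbers for an effect only at larger amounts of compound), compound 1 `O=C(O)CCCO/N=c1/ccn([C@@H]2O[C@H](COP(=O)(O)OP(=O)(O)OP(=O)(O)O)[C@@H](O)[C@H]2O)c(=O)[nH]1` gives 299 nM, compound 2 `O=c1[nH]/c(=N\OCCCc2ccc(F)cc2)ccn1[C@@H]1O[C@H](COP(=O)(O)OP(=O)(O)OP(=O)(O)O)[C@@H](O)[C@H]1O` gives 547 nM, and compound 3 `O=c1[nH]/c(=N\OCCCc2cccc([N+](=O)[O-])c2)ccn1[C@@H]1O[C@H](COP(=O)(O)OP(=O)(O)OP(=O)(O)O)[C@@H](O)[C@H]1O` gives 457 nM. Compound 3 thus holds the second highest of the three numbers; its nearest neighbour is compound 2 and its furthest is compound 1, and both gaps are within the scatter. The measured steps are a 1.8-fold higher number from compound 1 to compound 2 (0.26 log units; within the scatter), a 1.5-fold higher number from compound 1 to compound 3 (0.18 log units; within the scatter) and a 1.2-fold lower number from compound 2 to compound 3 (0.08 log units; within the scatter), all within the scatter, so exchanging the carboxy for either aryl group, or one aryl group for the other, has not moved this assay beyond its noise.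

Compound 4 `O=c1[nH]/c(=N\OCCCc2ccc([N+](=O)[O-])cc2)ccn1[C@@H]1O[C@H](COP(=O)(O)OP(=O)(O)OP(=O)(O)O)[C@@H](O)[C@H]1O` differs from compound 3 by 4-nitrophenyl in place of 3-nitrophenyl on a saturated chain carbon, three bonds along the chain from an oxygen. Among the measured compounds shown here, no measured step changes only the substituent position on the aryl ring, so the closest guide is the step from compound 2 to compound 3, where a different aryl substituent gave no change beyond the scatter. The step of a 1.0-fold lower number from compound 3 to compound 4 (0.01 log units; within the scatter) is therefore expected to stay within the scatter. For compound 4 the estimate in this assay is 450 nM, with a range from 200 nM to 1000 nM.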

Compound 4, half-maximal effective concentration: 458 nM
The estimate for compound 4 lay 1.0-fold (0.01 log units) below the measured number; the measured number falls inside the stated range.
By their numbers in this assay, from the lowest: compounds 1, 3, 4 and 2 (each within the scatter of the next).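

In this assay, among the compounds shown here, the step from the 3-nitrophenyl to the 4-nitrophenyl group is a 1.0-fold higher number from compound 3 to compound 4 (0.00 log units; within the scatter) and gives the first reading on where the substituent sits on the aryl ring: at this place on the chain, that move does not register beyond the scatter. Nitro in place of fluoro on an aromatic carbon gives a 1.2-fold lower number from compound 2 to compound 4 (0.08 log units; within the scatter) and 4-nitrophenyl in place of carboxy gives a 1.5-fold higher number from compound 1 to compound 4 (0.19 log units; within the scatter) and both also stay within the scatter, so none of the four end groups can be told apart here. No measured evidence bears on this result.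

Going by these compounds, whether an amine or a longer chain at this place would move the number beyond the scatter remains open. The compounds shown also leave open whether a change elsewhere on the shared core would do so.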